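Branched benzyl amide returns to the series

This account rests on a few compounds, and the source may have more. Where it says the series, first, only, none or still open, it means among the compounds named here.

Working notes on the amide substituent. Compound 1 `CC(C)C[C@H](N)c1cc(C(F)(F)F)ccc1N1CCN(C(=O)C(C)Cc2ccc(Cl)cc2O)CC1` gives 36 nM in an assay on HEK293 cells for displacement of a labelled ligand from Melanocortin receptor 4 (Homo sapiens); a lower number here means a stronger inhibitor, a higher number a weaker inhibitor. Compound 2 `CC(C)C[C@H](N)c1cc(C(F)(F)F)ccc1N1CCN(C(=O)CCC2CCCCC2)CC1` gives 5700 nM. Compound 3 `CC(C)C[C@H](N)c1cc(C(F)(F)F)ccc1N1CCN(C(=O)CSc2ccc(Cl)cc2Cl)CC1` gives 1500 nM, second highest of the three numbers; its step of a 42-fold higher number from compound 1 to compound 3 (1.62 log units; beyond the scatter) is large, while the step of a 3.8-fold lower number from compound 2 to compound 3 (0.58 log units; beyond the scatter) is modest. Compound 4 `COc1ccc(CC(C)C(=O)N2CCN(c3ccc(C(F)(F)F)cc3[C@@H](N)CC(C)C)CC2)cc1` carries the change (1-(4-methoxybenzyl)ethyl in place of ((2,4-dichlorophenyl)sulfanyl)methyl on a carbonyl carbon). For the measured compounds named here, the step that bears on it is a 42-fold higher number from compound 1 to compound 3 (1.62 log units; beyond the scatter), where a 1-(4-chloro-2-hydroxybenzyl)ethyl group on the carbonyl carbon went with a much lower number than the sulfanylmethyl group; the methoxy group of compound 4 has no measured counterpart, so the full return to compound 1 is uncertain. A large step to a lower number is expected, a 10-fold lower number from compound 3 to compound 4 (1.00 log units; beyond the scatter), and compound 4 is estimated at 150 nM with a range of 30 nM to 700 nM.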

Compound 4, inhibition constant: 120 nM
Estimate against measurement, compound 4: 1.3-fold (0.10 log units) above; the range from low to high includes it.
By their numbers in this assay, from the lowest: compound 1; then compound 4; then compound 3; then compound 2.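

The 1-(4-methoxybenzyl)ethyl group on the carbonyl carbon restores much of what the other amide substituents lacked in this assay, with a 13-fold lower number from compound 3 to compound 4 (1.10 log units; beyond the scatter) and a 48-fold lower number from compound 2 to compound 4 (1.68 log units; beyond the scatter). A low number at this position therefore does not require the 4-chloro-2-hydroxyphenyl group, although exchanging it for 4-methoxyphenyl still gives a 3.3-fold higher number from compound 1 to compound 4 (0.52 log units; beyond the scatter). Nothing available explains these steps.

Because the ring substituents differ together between compound 1 and compound 4, the contribution of each remains unresolved. A 4-chlorophenyl or a 2-hydroxyphenyl group would separate them, and a benzyl chain without the branching methyl would test the branch itself.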